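Aminophenyl to Pyrrolyl on the Carbonyl Carbon

This account rests on a few compounds, and the source may have more. Where it says the series, first, only, none or still open, it means among the compounds named here.

Compound 1 `COc1ccc(-c2cc3ccccc3nc2/C=C/C(=O)c2ccc(OC)cc2OC)cc1`: 7040 nM
Compound 2 `COc1ccc(-c2cc3ccccc3nc2/C=C/C(=O)c2ccc(N)cc2)cc1`: 7400 nM

Of the compounds shown here, two sharing one core have been tested in a functional assay on NCI-H460 cells (Homo sapiens) for antiproliferative activity, read by XTT assay, with a stated time of 72 h; on this read-out higher numbers stand for weaker inhibition and lower numbers for stronger inhibition. Compound 1 gives 7040 nM and compound 2 gives 7400 nM; the step of a 1.1-fold higher number from compound 1 to compound 2 (0.02 log units; within the scatter) is within the scatter, so the two numbers cannot be told apart. Compound 2 therefore stands level with compound 1, and neither is weaker or stronger on this evidence.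

Compound 3 `COc1ccc(-c2cc3ccccc3nc2/C=C/C(=O)c2ccc[nH]2)cc1` is the next compound, differing from compound 2 in one place: 1H-pyrrol-2-yl in place of 4-aminophenyl on a carbonyl carbon. Among the compounds with values here, no measured step changes a ring on the carbonyl carbon in this way; the only measured step, from compound 1 to compound 2, exchanged one six-membered ring for another and left the number unchanged within the scatter. That single step gives no reason to expect a large move in this assay , so the expected step of a 1.2-fold higher number from compound 2 to compound 3 (0.09 log units; within the scatter) is small. The estimate for compound 3 is 9000 nM, with a range from 3000 nM to 30000 nM.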

Compound 3, half-maximal inhibitory concentration: > 10000 nM
Compound 3 was reported as a limit; the forecaster's own chance of this, stated with the estimate: 10%; at least 1.1-fold (0.04 log units) between middle value and limit.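

In this assay, compound 3 is reported only as a limit, > 10000 nM, and not as an exact number. This is the first change shown that replaces a six-membered aromatic ring on this carbonyl carbon with a five-membered one, and it reads as an at least 1.3-fold higher number from compound 2 to compound 3 (0.13 log units; that floor lies within the scatter) and as an at least 1.4-fold higher number from compound 1 to compound 3 (0.15 log units; that floor lies within the scatter). Neither step shows stronger inhibition with 1H-pyrrol-2-yl, but both give only a floor, and the true size of the change stays unknown because the result for compound 3 is a limit: the limit of > 10000 nM in this assay, at which 1 of the 3 values shown sits.

The compounds shown leave open whether any group on this carbonyl carbon can move the number clearly beyond the scatter, in either direction, as the three results so far include no step of that kind. A methyl group, a 4-hydroxyphenyl group or a phenyl ring carrying a carboxylic acid in this place would show whether an aromatic ring is needed here at all and whether a different group on the ring can give stronger inhibition.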